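From fluoropyridine to methylpyridine at compound 4

The compounds below may be only part of what the source reports. "The series", "measured", "known", "first", "only" and "open" are said of these compounds alone.

Three compounds have values in an ADME assay (liver) for metabolic stability, with Liver microsome (Homo sapiens) as the target, using microsomes and NADPH, with a stated time of 30 min, tested at 1 uM (a lower number here means slower removal, a higher number faster removal of the compound), so far
compound 1 `Cc1csc(-c2cc(C(O)(C(F)(F)F)C(F)(F)F)cnc2N2CCN(S(=O)(=O)c3ccc(N)nc3)CC2)c1` gives 29 mL.min-1.g-1 
compound 2 `NC(=O)c1cccc(-c2cc(C(O)(C(F)(F)F)C(F)(F)F)cnc2N2CCN(S(=O)(=O)c3ccc(N)nc3)CC2)c1` gives 17 mL.min-1.g-1 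
compound 3 `Nc1ccc(S(=O)(=O)N2CCN(c3ncc(C(O)(C(F)(F)F)C(F)(F)F)cc3-c3cnccc3F)CC2)cn1` gives 17 mL.min-1.g-1 

The three numbers sit close together. The data show no change at the digits printed from compound 2 to compound 3 (within the scatter) and also a 1.7-fold lower number from compound 1 to compound 3 (0.23 log units; within the scatter) and thus compound 3 is not separated from either of the others. The remaining step is a 1.7-fold lower number from compound 1 to compound 2 (0.23 log units; within the scatter) and it too stays inside the usual variation.

Compound 4 `Cc1ccc(-c2cc(C(O)(C(F)(F)F)C(F)(F)F)cnc2N2CCN(S(=O)(=O)c3ccc(N)nc3)CC2)cn1` is the next case. It differs from compound 3 in one place 6-methylpyridin-3-yl in place of 4-fluoropyridin-3-yl on an aromatic carbon with 6-methylpyridin-3-yl in place of 4-fluoropyridin-3-yl on an aromatic carbon.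

All three measured steps change this same substituent, and none moves the number beyond the scatter. For the measured compounds named here, no measured compound carries the 6-methylpyridin-3-yl group, so the evidence is indirect. No real shift is therefore expected in this assay either way. The expected move is a 1.3-fold higher number from compound 3 to compound 4 (0.11 log units; within the scatter) and it is expected to remain within the scatter. For compound 4 the estimated value is 22 mL.min-1.g-1 with an expected range from 12 mL.min-1.g-1 to 40 mL.min-1.g-1 in this estimate.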

Compound 4, intrinsic clearance in microsomes: 43 mL.min-1.g-1
The estimate for compound 4 lay 2.0-fold (0.29 log units) below the measured number, and the stated range ends below it.
By their numbers in this assay, from the lowest: compounds 2, 3, 1 and 4 (each within the scatter of the next, the first and the last beyond it).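

For the compounds shown here, until now, no step at this position, ortho to a large group, had gone beyond the scatter in this assay, but a 2.5-fold higher number from compound 3 to compound 4 (0.40 log units; beyond the scatter) and a 2.5-fold higher number from compound 2 to compound 4 (0.40 log units; beyond the scatter) both do, so the group held here can shift the read-out, if modestly. The first of these steps keeps a six-membered aromatic ring with 1 hetero atom and exchanges 4-fluoropyridin-3-yl for 6-methylpyridin-3-yl, whereas a 1.5-fold higher number from compound 1 to compound 4 (0.17 log units; within the scatter) leaves compound 4 unseparated from the 4-methylthiophen-2-yl group of compound 1. The data offer no explanation for this shift.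

The two pyridines differ both in the substituent and in where it sits, and the compounds shown do not tell these apart. An unsubstituted pyridin-3-yl or a 6-methoxypyridin-3-yl group at this position would help to separate them.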